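The compounds below may be only part of what the source reports. "The series", "measured", "known", "first", "only" and "open" are said of these compounds alone.

Measured compounds and their values:
compound 1, `Nc1nc(NC2CC2)c2ncn(/C=C3/CC3(CO)CO)c2n1`, gives > 20000 nM
compound 2, `CN(C)c1nc(N)nc2c1ncn2/C=C1/CC1(CO)CO`, gives > 20000 nM
compound 3, `Nc1nc(NC2CCCC2)c2ncn(/C=C3/CC3(CO)CO)c2n1`, gives > 20000 nM

In an ADME assay on CCRF-HSB-2 cells (Homo sapiens) for cytotoxicity, with a stated time of 7 days (on this read-out higher numbers stand for lower toxicity in this test and lower numbers for higher toxicity in this test), compound 1 gives > 20000 nM, which is a limit of the assay and not a number. Compound 2 likewise gives > 20000 nM, again only a limit. Compound 3 gives > 20000 nM, once more a limit rather than a measured value. Compound 3 therefore stands at the same limit as the other two, as the limit of > 20000 nM in this assay, at which 3 of the 3 values shown sit, records.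

The three steps among the measured compounds are a step that the two limits leave unreadable from compound 1 to compound 2, a step that the two limits leave unreadable from compound 1 to compound 3 and a step that the two limits leave unreadable from compound 2 to compound 3; none of them can be read in size or direction, because every value involved is a limit (the limit of > 20000 nM in this assay, at which 3 of the 3 values shown sit).

Compound 4, `CCCCOc1nc(N)nc2c1ncn2/C=C1/CC1(CO)CO`, has not yet been measured. It differs from compound 3 as follows: butoxy in place of cyclopentylamino on an aromatic carbon. Within the data shown here, no measured step bears on a change of this kind, and the three known steps give no readable size to compare with. The expectation for compound 4 in this assay is therefore that it sits where compound 3 does; the expected step is a number no higher from compound 3 to compound 4 (the limit leaves the size open), none beyond the scatter. Compound 4 is estimated at 20000 nM, with a range from 8000 nM to 40000 nM.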

Compound 4, half-maximal cytotoxic concentration: > 20000 nM
Compound 4: no number, only a limit; the forecaster's own chance of this, stated with the estimate: 75%; the middle value sits exactly at the limit.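

In this assay compound 4 gives > 20000 nM, which is a limit of the assay and not a number. No step from compound 1, compound 2 or compound 3 to compound 4 can be read, because every value involved is a limit: the limit of > 20000 nM in this assay, at which 4 of the 4 values shown sit.

The compounds shown leave open whether these groups on the shared core differ at all in toxicity in this assay.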